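Notes on the step from compound 2 to compound 3

The source may report more compounds than this note shows. Statements on the series, on what has been measured and on what is new or still open speak of the compounds shown alone.

Among the compounds with values here, in a functional assay on NCI-H460 cells (Homo sapiens) for antiproliferative activity, read by sulforhodamine B assay, with a stated time of 48 h (a lower number here means a stronger inhibitor, a higher number a weaker inhibitor), compound 2 (`O=C(CCCCCCN1C(=O)/C(=N\O)c2cc([N+](=O)[O-])ccc21)NO`) gives 7710 nM as the highest of the two numbers so far, with compound 1 (`O=C(CCCCCCN1C(=O)/C(=N\O)c2cc(Br)ccc21)NO`) nearest at 970 nM in the same read-out. Compound 3 (`Cc1ccc2c(c1)/C(=N/O)C(=O)N2CCCCCCC(=O)NO`) has methyl in place of nitro on an aromatic carbon. Within the data shown here, only one measured step bears on this: a 7.9-fold higher number from compound 1 to compound 2 (0.90 log units; beyond the scatter) for nitro in place of bromo on an aromatic carbon, a modest step beyond the scatter. Among the measured compounds shown here, no methyl compound has been measured yet. A step of similar size toward a lower number is expected in this assay (a 5.1-fold lower number from compound 2 to compound 3 (0.71 log units; beyond the scatter) as estimated). For compound 3 the estimated value is 1500 nM (range 500 nM to 4500 nM).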

Compound 3, half-maximal inhibitory concentration: 2090 nM
Estimate against measurement, compound 3: 1.4-fold (0.14 log units) below; the measured number falls inside the stated range.
By their numbers in this assay, from the lowest: compound 1; then compound 3; then compound 2.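

In this assay this aromatic carbon now separates three groups rather than two. Methyl in place of nitro gives a 3.7-fold lower number from compound 2 to compound 3 (0.57 log units; beyond the scatter), while methyl in place of bromo gives a 2.2-fold higher number from compound 1 to compound 3 (0.33 log units; beyond the scatter), so methyl recovers only part of the gap between the nitro and bromo compounds, and bromo remains lowest of the three. No measurement at hand accounts for this order. Going by these compounds, whether methoxy or an amine on the same carbon would fall below compound 1 stays open, as does whether chloro would track bromo.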